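The source may report more compounds than this note shows. Statements on the series, on what has been measured and on what is new or still open speak of the compounds shown alone.

Measured so far:
compound 1 `CC(C)=CCCC1=CC[C@H](C(=O)N(C)O)[C@@H](c2ccccc2)C1` gives 2100 nM in an assay on isolated protein for inhibition of Apoptosis regulator Bcl-2 (Homo sapiens), read by fluorescence polarization, with stated times of 5 min and 10 min; on this read-out higher numbers stand for weaker inhibition and lower numbers for stronger inhibition.
Compound 2 `CC(C)=CCCC1=CC[C@@H](C(=O)N(C)C)[C@H](c2ccccc2)C1` sits at the limit > 23000 nM in this assay, a limit and not a number.
Compound 3 `CONC(=O)[C@@H]1CC=C(CCC=C(C)C)C[C@H]1c1ccccc1` gives 2700 nM in this assay.

Compound 1 and compound 3 give numbers within the scatter of each other, so no order between them is claimed; the remaining value, that of compound 2, is a limit of the assay (the limit of > 23000 nM in this assay, at which 1 of the 3 values shown sits). Among the compounds with values here, the only step between measured compounds that differ in one place is an at least 8.5-fold lower number from compound 2 to compound 3 (0.93 log units; beyond the scatter), a change of the substituent on the amide nitrogen of the shared core.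

Compound 4 `CC(C)=CCCC1=CC[C@H](C(=O)Nc2ccc(O)cc2)[C@@H](c2ccccc2)C1` carries (4-hydroxyphenyl)amino in place of hydroxy(methyl)amino on a carbonyl carbon. Within the data shown here, this again alters only the amide substituent on the carbonyl carbon, as the measured step did, but the group entering is an aromatic amide rather than a small alkoxy or hydroxy amine, for which the series holds no direct precedent. The measured step shows that the amide substituent can shift the number well beyond the scatter, yet its direction for an aryl amide is not fixed by the data. The expected step in this assay is therefore a 1.4-fold lower number from compound 1 to compound 4 (0.15 log units; within the scatter), with wide uncertainty. Compound 4 is estimated at 1500 nM, in the range 400 nM to 6000 nM.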

Compound 4, inhibition constant: > 23000 nM
Compound 4: a limit, no number; the forecaster's own chance of this, stated with the estimate: 10%; at least 15-fold (1.18 log units) between middle value and limit.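

In this assay, placing (4-hydroxyphenyl)amino in place of hydroxy(methyl)amino on a carbonyl carbon gives an at least 10-fold higher number from compound 1 to compound 4 (1.03 log units; beyond the scatter), so this position does not accept every amide substituent that carries a hydrogen-bond donor. Compound 4 stands at a limit and not at a number, so the step gives only a minimum size: the limit of > 23000 nM in this assay, at which 2 of the 4 values shown sit. An aromatic ring on the amide nitrogen therefore joins the dimethylamino group of compound 2 at that limit, while the hydroxy(methyl)amino of compound 1 and the methoxyamino of compound 3 both give numbers.

No order between compound 2 and compound 4 can be read, as both are limits. From the compounds shown here alone, whether the step belongs to the ring or to its hydroxy stays open; a plain phenylamino or a methylamino group on the same carbonyl carbon would bear on this.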